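This account rests on a few compounds, and the source may have more. Where it says the series, first, only, none or still open, it means among the compounds named here.

Values measured in a functional assay on BCG823 cells (Homo sapiens) for cytotoxicity, read by MTT assay, with a stated time of 72 h; a lower number here means a stronger inhibitor, a higher number a weaker inhibitor:

Compound 1 `CCOC(=O)C(COC(=O)c1ccccc1OC(C)=O)c1ccc(F)cc1`: > 0.01 ug/mL
Compound 2 `CCOC(=O)C(COC(=O)/C=C/c1ccc(OC)c(OC)c1)c1ccc(F)cc1`: > 0.01 ug/mL
Compound 3 `CCOC(=O)C(COC(=O)c1ccccc1)c1ccc(C(F)(F)F)cc1`: > 0.01 ug/mL

Compound 3 has no exact number: its > 0.01 ug/mL is a limit of the assay. Going by the values given here, the whole set sits at one mark, (the limit of > 0.01 ug/mL in this assay, at which 3 of the 3 values shown sit), so no compound can be ranked against another. Compound 4 `CCOC(=O)C(COC(=O)c1ccccc1OC(C)=O)c1ccc(C(F)(F)F)cc1` differs from compound 3 at one place, with acetoxy in place of hydrogen on an aromatic carbon, turning phenyl into 2-acetoxyphenyl: acetoxy in place of hydrogen on an aromatic carbon. Compound 1 also carries 2-acetoxyphenyl, and its > 0.01 ug/mL is likewise only a limit. The expected step that the limit leaves unreadable from compound 3 to compound 4 is none beyond the scatter in this assay, with no direction expected. For compound 4 the estimated value is 0.02 ug/mL, with an expected range of 0.01 ug/mL to 0.2 ug/mL.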

Compound 4, half-maximal inhibitory concentration: > 0.01 ug/mL
Compound 4 was reported as a limit; the forecaster's own chance of this, stated with the estimate: 85%; the middle value lies beyond the limit too.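

No step can be read from compound 3 or compound 1 to compound 4, because each value is a limit and not a number: the limit of > 0.01 ug/mL in this assay, at which 4 of the 4 values shown sit.
The compounds shown leave open how strong each one actually is, and whether acetoxy or trifluoromethyl changes that.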